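A few compounds are considered here, and "the series" means these few. Any claim that something is new, unique, unknown or untested is made for them only; others in the source may bear on it.

The series shares one core, a 2,3-dichloro-4-(2-methylenebutanoyl)phenoxyacetamide, and differs only in the group carried on the amide nitrogen. In a functional assay on CLL cells (Homo sapiens) for cytotoxicity, read by MTT assay, with a stated time of 48 h (a higher number here means that more compound is needed for the effect, a lower number that less compound is needed), compound 1 `C=C(CC)C(=O)c1ccc(OCC(=O)Nc2ccc3c(C)cc(=O)oc3c2)c(Cl)c1Cl` gives 2800 nM, compound 2 `C=C(CC)C(=O)c1ccc(OCC(=O)Nc2ccc(O)c([N+](=O)[O-])c2)c(Cl)c1Cl` gives 7400 nM, and compound 3 `C=C(CC)C(=O)c1ccc(OCC(=O)Nc2ccc(C(=O)O)cn2)c(Cl)c1Cl` gives 14900 nM. Compound 3 thus returns the highest number of the three, though its gap to compound 2 lies within the scatter, while its gap to compound 1 lies beyond it. Compound 4 `C=C(CC)C(=O)c1ccc(OCC(=O)Nc2ccc(C(C)=O)cc2)c(Cl)c1Cl` has not yet been measured in this assay. It differs from compound 3 in one place: 4-acetylphenyl in place of 5-carboxypyridin-2-yl on an amide-type nitrogen. Going by the values given here, no step between measured compounds exists for this change, so the expectation rests on the spread of the three numbers and on the fact that compound 3, the bearer of the group that leaves, gives 14900 nM. The step from compound 3 to compound 4 is expected to be a modest move toward a lower number, a 2.5-fold lower number from compound 3 to compound 4 (0.40 log units; beyond the scatter), of a size that may or may not exceed the scatter. Compound 4 is estimated to give 6000 nM, within a range from 1800 nM to 18000 nM.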

Compound 4, half-maximal effective concentration: 3900 nM
Compound 4: middle estimate off by 1.5-fold (0.19 log units), on the high side; the measured number falls inside the stated range.
By their numbers in this assay, from the lowest: compounds 1, 4, 2 and 3 (each within the scatter of the next, the first and the last beyond it).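

In this assay, the exchange of 5-carboxypyridin-2-yl for 4-acetylphenyl on the amide-type nitrogen gives a 3.8-fold lower number from compound 3 to compound 4 (0.58 log units; beyond the scatter), the first step available at this position. It shows that the number responds to the group at this place even when the heavy-atom count stays at 9 and a single six-membered aromatic ring and 1 double bond outside aromatic rings are kept on both sides. The change also swaps ring and oxygen atoms and removes the hydrogen-bond donor, and no measurement at hand accounts for the step.

Which of these differences carries the step stays open. A carboxylic acid on a ring of carbon only, or an acetyl group on a ring with 1 hetero atom, would separate them, and an amine in place of the acetyl group is also untested here.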